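This account rests on a few compounds, and the source may have more. Where it says the series, first, only, none or still open, it means among the compounds named here.

Measured so far:
- compound 1, `CSc1nc(NCc2ccccc2)c2c(n1)C(=O)C(c1ccccc1)=[N+]2[O-]`, with 81000 nM in a functional assay on T47D cells (Homo sapiens) for antiproliferative activity, read by sulforhodamine B assay, with a stated time of 48 h; on this read-out lower numbers stand for stronger inhibition of growth and higher numbers for weaker inhibition of growth
- compound 2, `Nc1nc(NCc2ccccc2)nc2c1[N+]([O-])=C(c1ccccc1)C2=O`, with 4000 nM in this assay

Compound 2 stands at the lower of the two numbers measured in this assay; compound 1 gives the higher number, and the gap between them lies beyond the usual scatter of this assay. For the measured compounds named here, no step between two measured compounds that differ in only one place is available, so there is no measured guide for what a single change at the amine does.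

Compound 3, `Nc1nc(NCCN2CCCC2)nc2c1[N+]([O-])=C(c1ccccc1)C2=O`, is the next compound. It differs from compound 2 in one place: (pyrrolidin-1-yl)methyl in place of phenyl on a saturated chain carbon bound to a nitrogen on an aromatic ring. Going by the values given here, since no measured step covers this kind of change, the account can only state an expectation. Compound 3 is expected to land close to compound 2, with a step of a 1.3-fold higher number from compound 2 to compound 3 (0.10 log units; within the scatter) that need not go beyond the scatter in either direction. For compound 3 the estimate in this assay is therefore 5000 nM, within a range from 1500 nM to 25000 nM.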

Compound 3, concentration for 50% growth inhibition: 13000 nM
For compound 3 the middle estimate is 2.6-fold (0.41 log units) below the measured one; the range from low to high includes it.
By their numbers in this assay, from the lowest: compound 2; then compound 3; then compound 1.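

In this assay, placing (pyrrolidin-1-yl)methyl in place of phenyl on a saturated chain carbon bound to a nitrogen on an aromatic ring gives the first step across a single change in this series, a 3.3-fold higher number from compound 2 to compound 3 (0.51 log units; beyond the scatter), so this position does respond to what it carries, though modestly. The groups that leave and enter match in heavy atoms, so that count alone does not set the number here; what differs is an aromatic ring of carbon only against a non-aromatic ring with a hetero atom and a hydrogen-bond acceptor, and the data do not show which of these matters. Nothing available explains the step.

As far as these compounds go, with one pair at this position, it remains open whether the weaker inhibition of growth follows the departure of phenyl or the arrival of the pyrrolidine. A phenethyl group, a piperidine or morpholine on the same ethyl chain, or a longer chain bearing the pyrrolidine would each bear on that question.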